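From allylamino to cyclopropylamino on a shared core

The source may hold more compounds than are shown below. What is called first, only, known or untested is meant among the compounds shown, and "the series" means these compounds.

compound 1 (`CCNC1=NS(=O)(=O)c2cc(Cl)c(Cl)cc2N1`): 1000 nM
compound 2 (`C=CCNC1=Nc2cc(Cl)c(Cl)cc2S(=O)(=O)N1`): 1200 nM

Both values come from a functional assay (aorta) with Rattus norvegicus as the target, with a stated time of 90 min, at 37 degrees C (a lower number here means that less compound is needed, a higher number that more compound is needed for the effect), and the read-out is a half-maximal effective concentration. There compound 2 at 1200 nM stands within the usual scatter of compound 1 at 1000 nM and so the two cannot be ranked. Not yet measured is compound 3 (`O=S1(=O)NC(NC2CC2)=Nc2cc(Cl)c(Cl)cc21`), which is reached from compound 2 by a single change (cyclopropyl in place of allyl on an amine nitrogen). In words, cyclopropyl stands in place of allyl on an amine nitrogen. For the measured compounds named here, no step between measured compounds speaks to this change, so the expectation can lean only on the values in hand. With compound 2 at 1200 nM as the starting point, no shift beyond the scatter is expected in this assay and no direction is favoured. The estimated step is a 1.1-fold lower number from compound 2 to compound 3 (0.04 log units; within the scatter) and it is expected to stay within the scatter. For compound 3 the estimated value is 1100 nM with an expected range (450 nM to 2700 nM).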

Compound 3, half-maximal effective concentration: > 30000 nM
Compound 3: a limit, no number; the forecaster's own chance of this, stated with the estimate: 3%; middle value at least 27-fold (1.43 log units) from the limit.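

In this assay, cyclopropyl in place of allyl on an amine nitrogen gives an at least 25-fold higher number from compound 2 to compound 3 (1.39 log units; beyond the scatter), even though the two groups have the same count of heavy atoms, all of them carbon. In the computed difference, a three-membered ring enters and a double bond leaves. Compound 3 carries a limit of the assay and not a number: the limit of > 30000 nM in this assay, at which 1 of the 3 values shown sits. The values of compound 1 and compound 2 lay within the scatter of each other and gave no sign of such a step, whereas this result shows that allyl and cyclopropyl are far from interchangeable at this amine nitrogen.

The compounds shown leave open whether the step follows the arrival of the three-membered ring or the departure of the double bond, a question that a saturated propyl chain or a cyclobutyl ring on the same nitrogen would help to settle. They also leave open whether a larger ring or a longer chain at this place would give a number in this assay or another limit.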